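Adding a Second Trifluoromethyl to a Tolerated Urea

This account rests on a few compounds, and the source may have more. Where it says the series, first, only, none or still open, it means among the compounds named here.

Compound 1 (`O=C(Nc1cccc(-n2cc(-c3ccncc3)c(-c3ccc(Cl)c(O)c3)n2)c1)Nc1cccc(C(F)(F)F)c1`) is a urea carrying a single trifluoromethyl group on its outer ring. In a functional assay on OVCAR-4 cells (Homo sapiens) for inhibition, read by sulforhodamine B assay, with a stated time of 48 h (a lower number here means that less compound is tolerated, a higher number that more compound is tolerated), compound 1 gives > 32500 nM, which is a limit of the assay rather than a number. Two close relatives have been measured alongside it. Compound 2 (`O=C(Nc1cccc(-n2cc(-c3ccncc3)c(-c3ccc(Cl)c(O)c3)n2)c1)Nc1ccc(Cl)c(Cl)c1`) swaps that outer ring for a 3,4-dichlorophenyl on the same amide-type nitrogen. In this assay compound 2 gives > 32500 nM, again a limit. Compound 3 (`COc1cc(-c2nn(-c3cccc(NC(=O)c4ccc(Cl)c(C(F)(F)F)c4)c3)cc2-c2ccncc2)ccc1Cl`) replaces the urea with an amide and carries a methoxy in place of the hydroxyl. In this assay compound 3 gives > 32500 nM, also a limit. Among the measured compounds shown here, the one single-point step, a step that the two limits leave unreadable from compound 1 to compound 2, cannot be sized, since (the limit of > 32500 nM in this assay, at which 3 of the 3 values shown sit).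

Compound 4 (`O=C(Nc1cccc(-n2cc(-c3ccncc3)c(-c3ccc(Cl)c(O)c3)n2)c1)Nc1cc(C(F)(F)F)cc(C(F)(F)F)c1`) differs from compound 1 by trifluoromethyl in place of hydrogen on an aromatic carbon. For the measured compounds named here, no measured step shows that a change on this ring moves the read-out, so no shift beyond the scatter is expected, meaning a step that the limit leaves unreadable from compound 1 to compound 4. Compound 4 is therefore expected to sit near 40000 nM, within 20000 nM to 100000 nM, most likely as a limit once more.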

Compound 4, concentration lethal to 50% of the cells: 23900 nM
Beside the measured number, compound 4's estimate is 1.7-fold (0.22 log units) above it; the measured number falls inside the stated range.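

In this assay compound 4 gives 23900 nM, and it is the only one of the four compounds shown that gives a number rather than a limit. Among the compounds shown here, this places a measured value on this outer ring for the first time, and the change of hydrogen to trifluoromethyl gives an at least 1.3-fold lower number from compound 1 to compound 4 (0.13 log units; that floor lies within the scatter), so the data show a direction but not a shift beyond the scatter. The true size of the step stays unknown, and only a floor can be read: the limit of > 32500 nM in this assay, at which 3 of the 4 values shown sit.

The compounds shown leave open whether a trifluoromethyl is needed at this place on the ring, or whether a methyl, a methoxy or an amine there would also give a measurable number. They also leave open whether the same addition would give a number on the amide of compound 3.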